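A few compounds are considered here, and "the series" means these few. Any claim that something is new, unique, unknown or untested is made for them only; others in the source may bear on it.

In a functional assay on L1210 cells (Mus musculus) for cytotoxicity (on this read-out lower numbers stand for an effect already at smaller amounts and higher numbers for an effect only at larger amounts of compound), two compounds have been measured so far. Compound 1 `CCCC(O)C1=CC(=O)c2c(OC)ccc(OC)c2C1=O` gives 0.409 ug/mL, and compound 2 `COc1cc(C(C)O)c(OC)c2c1C(=O)C=CC2=O` gives 0.132 ug/mL. Compound 1 therefore holds the higher of the two numbers and needs the larger amount for its effect, a gap that lies beyond the usual scatter. Compound 3 `CCCCCC(O)C1=CC(=O)c2c(OC)ccc(OC)c2C1=O` keeps the core of compound 1 and lengthens its chain: ethyl in place of hydrogen on a saturated chain carbon, four bonds along the chain from a double-bonded ring carbon and an oxygen on a saturated carbon. Read one bond further out, the same change turns propyl into pentyl. Within the data shown here, compound 2 differs from compound 1 in more than one place, so no measured pair shows what a longer chain does on its own. With nothing to size the change, the expectation in this assay is no step beyond the scatter, in either direction. The estimated change is a 1.0-fold lower number from compound 1 to compound 3 (0.01 log units; within the scatter). For compound 3 the expected value is 0.4 ug/mL, within an estimated range of 0.15 ug/mL to 1.1 ug/mL.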

Compound 3, concentration for half-maximal effect: 0.378 ug/mL
Compound 3: middle estimate off by 1.1-fold (0.02 log units), on the high side; the measured number falls inside the stated range.
By their numbers in this assay, from the lowest: compound 2; then compounds 3 and 1 (each within the scatter of the next).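

Among these compounds, the step of a 1.1-fold lower number from compound 1 to compound 3 (0.03 log units; within the scatter) is the first direct reading of what a longer chain does on its own in this assay. At this saturated chain carbon, ethyl in place of hydrogen, which turns propyl into pentyl, leaves the number within the scatter, so this added length on the core of compound 1 brings no measurable shift in the read-out. No supporting measurement is available to explain why the number holds steady.

From the compounds shown here alone, whether a still longer chain, such as octyl, or a different kind of group at this carbon, such as an amine or a carboxylic acid, would move the number remains open. Also open, going by these compounds, is whether the same change, read as methyl to propyl on compound 2, would leave its number just as steady.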